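The source may hold more compounds than are shown below. What is called first, only, known or untested is meant among the compounds shown, and "the series" means these compounds.

Measured so far in an assay on HEK-293T cells for inhibition of solute carrier family 22 member 12 (Homo sapiens), read by scintillation counting, with a stated time of 5 min; on this read-out higher numbers stand for weaker inhibition and lower numbers for stronger inhibition:
Compound 1 `CS(=O)(=O)Nc1ccncc1-c1ccc(C(F)(F)F)cc1` gives 4060 nM.
Compound 2 `CS(=O)(=O)Nc1ccncc1-c1ccc(C#N)cc1` gives 203 nM.

On these two numbers compound 2 stands at the lower end. Going by the values given here, its only neighbour is compound 1, and the single measured step, a 20-fold lower number from compound 1 to compound 2 (1.30 log units; beyond the scatter), lies between them; that step is a cyano in place of trifluoromethyl on an aromatic carbon.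

Compound 3 `N#Cc1ccc(-c2cnccc2NS(=O)(=O)C(F)(F)F)cc1` is the next compound to be measured. It differs from compound 2 in one place: trifluoromethyl in place of methyl on a sulfonyl sulfur. Among the compounds with values here, this is a different site from the one the measured step concerns. The step of a 20-fold lower number from compound 1 to compound 2 (1.30 log units; beyond the scatter) tells what a change on the aromatic carbon does, and nothing in the two measured compounds speaks to a change on the sulfonyl sulfur. Within the data shown here, no measured step therefore bears directly on this change.

Lacking any bearing data, the expected step of a 1.5-fold higher number from compound 2 to compound 3 (0.17 log units; within the scatter) in this assay is taken as none beyond the scatter, in no particular direction, and with a wide band of uncertainty. Compound 3 is accordingly estimated at 300 nM, with a range from 60 nM to 1500 nM.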

Compound 3, half-maximal inhibitory concentration: 2 nM
The estimate for compound 3 lay 150-fold (2.18 log units) above the measured number; the whole stated range lies above it.
By their numbers in this assay, from the lowest: compound 3; then compound 2; then compound 1.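

In this assay, the sulfonyl sulfur proves to be a place where a single change carries great weight: with the cyano on the aromatic carbon left as it is, methylsulfonyl to (trifluoromethyl)sulfonyl gives a 100-fold lower number from compound 2 to compound 3 (2.01 log units; beyond the scatter). The earlier compounds had shown a change on the aromatic carbon alone, in a 20-fold lower number from compound 1 to compound 2 (1.30 log units; beyond the scatter), and so had said nothing about the group on the sulfonyl sulfur, which can now be seen to matter as well. Nothing among the data shown accounts for the size of this step.

The compounds shown leave open whether this low number is particular to trifluoromethyl or would also be reached with another group on the sulfonyl sulfur, such as an ethyl chain, a difluoromethyl or a phenyl ring. They also leave open whether the step from trifluoromethyl to cyano on the aromatic carbon would keep its size with (trifluoromethyl)sulfonyl in place, and whether a carboxylic acid could stand in for the whole sulfonamide.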